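This account rests on a few compounds, and the source may have more. Where it says the series, first, only, none or still open, it means among the compounds named here.

Three compounds built on one shared core were tested in a functional assay on C6 cells (Rattus norvegicus) for cytotoxicity, read by MTT assay, with a stated time of 24 h, tested at 200 ug/mL; on this read-out higher numbers stand for a weaker effect at the one concentration tested and lower numbers for a stronger effect. Compound 2 `COc1ccc(-c2cs/c(=N/NC(=O)CSc3nnc(C)s3)n2-c2ccccc2)cc1` gives 22.2%. Compound 1 `Cc1nnc(SCC(=O)N/N=c2/scc(-c3ccc(F)cc3)n2-c2ccccc2)s1` carries, relative to compound 2, (fluoro in place of methoxy on an aromatic carbon); in this assay compound 1 gives 26.5%, and that change produced a number 4.3 percentage points higher from compound 2 to compound 1 (within the scatter). Compound 3 `COc1ccc(-c2cs/c(=N/NC(=O)CSc3ncccn3)n2-c2ccccc2)cc1` differs from compound 2 by pyrimidin-2-yl in place of 5-methyl-1,3,4-thiadiazol-2-yl on a sulfur; in this assay compound 3 gives 37.6%, a step of a number 15.4 percentage points higher from compound 2 to compound 3 (beyond the scatter); its number is the highest of the three, separated from both others by more than the scatter.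

Compound 4 `O=C(CSc1ncccn1)N/N=c1/scc(-c2ccc(F)cc2)n1-c1ccccc1` has not yet been measured. Among the measured compounds shown here, it differs from compound 3 by fluoro in place of methoxy on an aromatic carbon, the same change, at the same place, as the one from compound 2 to compound 1; the two pairs differ in their cores by pyrimidin-2-yl in place of 5-methyl-1,3,4-thiadiazol-2-yl on a sulfur. The step expected from this change in this assay is a number 3.4 percentage points higher from compound 3 to compound 4 (within the scatter), set beside the earlier a number 4.3 percentage points higher from compound 2 to compound 1 (within the scatter), which stayed within the scatter. On that basis compound 4 is estimated at 41%, with a likely range from 30% to 54%.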

Compound 4, a percentage reported as activity, at one concentration (the size of the read-out at that concentration, not a potency): 32.2%
Compound 4: middle estimate off by 8.8 percentage points, on the high side; measured number inside the range.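

In this assay the change from 4-methoxyphenyl to 4-fluorophenyl gives a number 5.4 percentage points lower from compound 3 to compound 4 (within the scatter), and on both cores the step stays small enough to be read as no clear change, so the two cores agree here: the same change on two cores in this assay, a number 4.3 percentage points higher (within the scatter) from compound 2 to compound 1 and a number 5.4 percentage points lower (within the scatter) from compound 3 to compound 4, 9.7 percentage points apart, within the scatter of two such steps. The swap of the group on the sulfur gives a number 5.7 percentage points higher from compound 1 to compound 4 (within the scatter), and although only the earlier step on the methoxy core passed the scatter, the two steps cannot be told apart: the same change on two cores in this assay, a number 15.4 percentage points higher (beyond the scatter) from compound 2 to compound 3 and a number 5.7 percentage points higher (within the scatter) from compound 1 to compound 4, 9.7 percentage points apart, within the scatter of two such steps. Two pairs read at a single concentration do not show that either change would behave the same way on a further core, and they give no measure of potency.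

The compounds shown leave open how an amine or a carboxylic acid would read in place of the fluoro or methoxy group. They also leave open what a longer chain would do in place of the pyrimidin-2-yl group on the sulfur.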